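The compounds below may be only part of what the source reports. "The series", "measured", "known", "first", "only" and "open" are said of these compounds alone.

Three compounds share one core and differ only in the aromatic piece joined to it through the thioether. Compound 1 `Nc1ccccc1NC(=O)c1ccc(CSc2nccc(C(F)(F)F)n2)cc1` and compound 2 `Nc1ccccc1NC(=O)c1ccc(CSc2ccc(C(F)(F)F)cn2)cc1` each carry a trifluoromethyl group on that piece, while compound 3 `CC(C)(C)c1ccc(SCc2ccc(C(=O)Nc3ccccc3N)cc2)cc1` carries a tert-butyl group instead. In a functional assay on A549 cells (Homo sapiens) for inhibition, read by CCK-8 assay, with a stated time of 72 h, tested at 8 uM (on this read-out higher numbers stand for more inhibition of growth at the one concentration tested and lower numbers for less inhibition of growth), compound 1 gives 95.1%, compound 2 gives 38.9%, and compound 3 gives 67%. Compound 3 thus stands second of the three: compound 1 is above it by a margin beyond the usual scatter, and compound 2 is below it by a margin of the same size, also beyond the scatter.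

Compound 4 `Nc1ccccc1NC(=O)c1ccc(CSc2ccc(Cl)cc2)cc1` is the next compound to be tested in this assay. It differs from compound 3 in one place: chloro in place of tert-butyl on an aromatic carbon. Among the compounds with values here, no measured pair shows a change of this kind, so the effect of swapping one such group for another cannot be read from the numbers so far. The step from compound 3 to compound 4 is expected to be small, a number 7 percentage points lower from compound 3 to compound 4 (within the scatter), and not beyond the scatter. Compound 4 is therefore estimated to give 60%, with a range from 35% to 85%.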

Compound 4, percent growth inhibition at one concentration: 50.4%
The estimate for compound 4 lay 9.6 percentage points above the measured number; low and high end bracket the measured number.
By their numbers in this assay, from the lowest: compound 2; then compound 4; then compound 3; then compound 1.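

Within the data shown here, this is the first pair that differs in one place only, so the aromatic carbon para to a large group can now be read directly: in this assay, chloro in place of tert-butyl gives a number 16.6 percentage points lower from compound 3 to compound 4 (beyond the scatter). The step is modest but lies beyond the usual scatter, so the group on this carbon does affect growth inhibition, and 1 heavy atom of chlorine does not match what the tert-butyl group, with its 4 heavy atoms, gives here. Nothing measured here gives a reason for this step.

Compound 1 and compound 2 differ from this pair in more than one place, so their steps to it cannot be read. From the compounds shown here alone, how a methoxy group, an amine or a carboxylic acid on this same carbon would compare remains open, as does trifluoromethyl there.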